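Butoxy for dimethylamino at the assay limit

The compounds below may be only part of what the source reports. "The series", "measured", "known", "first", "only" and "open" are said of these compounds alone.

In a functional assay on PC-3 cells (Homo sapiens) for antiproliferative activity, with a stated time of 48 h (on this read-out higher numbers stand for weaker inhibition and lower numbers for stronger inhibition), compound 1 `CCOC(=O)c1ccc(-c2ccc(N(C)C)nn2)cc1` gives > 25000 nM as a limit and not a number. Compound 2 `COC(=O)c1ccc(-c2ccc(N(C)C)nn2)cc1` gives > 25000 nM as a limit too. Compound 3 `FC(F)(F)c1cccc(-c2ccc(N3CCCC3)nn2)c1` gives > 25000 nM as a limit as well. Compound 1 thus stands at the limit of > 25000 nM in this assay, at which 3 of the 3 values shown sit, and has no number by which to rank it.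

Compound 4 `CCCCOc1ccc(-c2ccc(C(=O)OCC)cc2)nn1` keeps the core of compound 1 and carries one change: butoxy in place of dimethylamino on an aromatic carbon in all, butoxy in place of dimethylamino on an aromatic carbon. Going by the values given here, the only measured step is a step that the two limits leave unreadable from compound 1 to compound 2 and it does not touch this place, so no measured size bears directly on the change.

Resting on compound 1 and its > 25000 nM limit, no step beyond the scatter is expected in this assay for this change, in either direction. The estimated step is a step that the limit leaves unreadable from compound 1 to compound 4 and it is expected to stay hard to read. For compound 4 the estimate is 30000 nM with an expected range from 12000 nM to 60000 nM and a good chance of only a limit.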

Compound 4, half-maximal inhibitory concentration: > 25000 nM
Compound 4: no number, only a limit (the forecaster's own chance of this, stated with the estimate: 70%); the middle value lies beyond the limit too.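

Compound 1 and compound 4 both stand at a limit and not at a number in this assay, and the step between them cannot be read. The compounds shown leave open how butoxy and dimethylamino would rank against each other, as all of them share one limit: the limit of > 25000 nM in this assay, at which 4 of the 4 values shown sit.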